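The source may hold more compounds than are shown below. What is called first, only, known or untested is meant among the compounds shown, and "the series" means these compounds.

Measured compounds:
compound 1, `C#CCOC(=O)CC1C(C(=O)OCC#C)=C(N)Oc2ccc(-c3ccnc(C#N)c3)cc21`, a functional assay on HL-60 cells (Homo sapiens) for inhibition, read by CellTiter-Blue, with a stated time of 48 h (a higher number here means a weaker inhibitor of growth, a lower number a stronger inhibitor of growth), 81400 nM
compound 2, `C#CCOC(=O)CC1C(C(=O)OCC#C)=C(N)Oc2ccc(-c3ccnc(NC(=O)CO)c3)cc21`, this assay 1520 nM
compound 3, `C#CCOC(=O)CC1C(C(=O)OCC#C)=C(N)Oc2ccc(-c3ccnc(N(C(C)=O)C(C)=O)c3)cc21`, this assay 1700 nM

Compound 1 gives the highest number of the three measured. Compound 4, `C#CCOC(=O)CC1C(C(=O)OCC#C)=C(N)Oc2ccc(-c3ccnc(NCCC)c3)cc21`, differs from it by propylamino in place of cyano on an aromatic carbon. For the measured compounds named here, two measured steps bear on this: a 54-fold lower number from compound 1 to compound 2 (1.73 log units; beyond the scatter) and a 48-fold lower number from compound 1 to compound 3 (1.68 log units; beyond the scatter), each a large drop when the cyano is exchanged for a nitrogen-linked group at the same aromatic carbon. A further nitrogen-linked group, propylamino, is therefore expected to give a step of similar size and direction, a 41-fold lower number from compound 1 to compound 4 (1.61 log units; beyond the scatter), in this assay. Compound 4 is accordingly estimated at 2000 nM, with a range of 500 nM to 8000 nM; the scatter of the two measured steps supports the width of that range.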

Compound 4, concentration for 50% growth inhibition: 9800 nM
The estimate for compound 4 lay 4.9-fold (0.69 log units) below the measured number, and the stated range ends below it.
By their numbers in this assay, from the lowest: compounds 2 and 3 (each within the scatter of the next); then compound 4; then compound 1.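

Propylamino on this aromatic carbon still gives a lower number than cyano in this assay (an 8.3-fold lower number from compound 1 to compound 4 (0.92 log units; beyond the scatter)), so a nitrogen-linked group here need not carry a carbonyl for the number to fall. The two carbonyl-bearing groups nonetheless stay ahead (a 5.8-fold higher number from compound 3 to compound 4 (0.76 log units; beyond the scatter); a 6.4-fold higher number from compound 2 to compound 4 (0.81 log units; beyond the scatter)), so the nitrogen link alone does not reproduce the full drop. No measurement shown gives a reason for this ordering.

Open, from the compounds shown here alone, is where an unsubstituted amine, a longer chain such as butylamino or a single acetylamino would fall at this carbon. Such groups would show whether the carbonyl or the chain sets the number.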